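Swapping Methoxy for Chloro on the Benzyl Arm

The compounds below may be only part of what the source reports. "The series", "measured", "known", "first", "only" and "open" are said of these compounds alone.

Of the compounds shown here, three built on one shared core have been tested in a functional assay on MCF7 cells (Homo sapiens) for cytotoxicity, read by MTT assay, with a stated time of 24 h, tested at 16 ug/mL; a higher number here means a stronger effect of the compound at the concentration tested, a lower number a weaker effect. Compound 1 `CN1CCN(CC(=O)Nc2ccc(-c3nc(-c4ccccc4)c(-c4ccccc4)n3C)cc2)CC1` gives 30.1%. Compound 2 `CN(C)/C=C/N1CCN(CC(=O)Nc2ccc(-c3nc(-c4ccccc4)c(-c4ccccc4)n3C)cc2)CC1` gives 19.4% in this assay, which is a step of a number 10.7 percentage points lower from compound 1 to compound 2 (beyond the scatter). Compound 3 `COc1ccc(CN2CCN(CC(=O)Nc3ccc(-c4nc(-c5ccccc5)c(-c5ccccc5)n4C)cc3)CC2)cc1` gives 12% in this assay; this is the lowest of the three numbers, reached by a step of a number 18.1 percentage points lower from compound 1 to compound 3 (beyond the scatter) and a step of a number 7.4 percentage points lower from compound 2 to compound 3 (within the scatter), the latter within the scatter.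

Compound 4 `Cn1c(-c2ccc(NC(=O)CN3CCN(Cc4ccc(Cl)cc4)CC3)cc2)nc(-c2ccccc2)c1-c1ccccc1` has not yet been measured. It differs from compound 3 in one place: chloro in place of methoxy on an aromatic carbon. Going by the values given here, none of the measured steps touches this part of the molecule; each of them exchanges the whole group on the amine nitrogen in the ring, whereas here only the substituent on the 4-methoxybenzyl is swapped. Among the compounds with values here, there is therefore no measured step that bears on this change, and no step beyond the scatter is expected in this assay in either direction. The expected value for compound 4 is 15%, with a range from 3% to 32%. This expectation amounts to a step of a number 3 percentage points higher from compound 3 to compound 4 (within the scatter).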

Compound 4, a percentage reported as activity, at one concentration (the size of the read-out at that concentration, not a potency): 46.2%
For compound 4 the middle estimate is 31.2 percentage points below the measured one; measured number above the stated range.
By their numbers in this assay, from the lowest: compounds 3 and 2 (each within the scatter of the next); then compound 1; then compound 4.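

Going by these compounds alone, replacing methoxy with chloro on the aromatic ring gives a number 34.2 percentage points higher from compound 3 to compound 4 (beyond the scatter) in this assay, showing that this one outer substituent can change the read-out, whereas the earlier steps exchanged the whole group on the ring nitrogen. The benzyl arm does not by itself bring a lower number: 4-chlorobenzyl gives a number 26.8 percentage points higher from compound 2 to compound 4 (beyond the scatter) and a number 16.1 percentage points higher from compound 1 to compound 4 (beyond the scatter), while the 4-methoxybenzyl of compound 3 lay lower than the methyl of compound 1. Nothing available explains why this exchange has such an effect.

On these data alone, it remains open whether chloro is special or methoxy is the outlier, and a benzyl group carrying only hydrogen, or one carrying fluoro, bromo or methyl in the same place, would help to separate the two. Each number also comes from one concentration, so the order of these compounds says nothing about their potency.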